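The compounds below may be only part of what the source reports. "The series", "measured", "known", "first", "only" and "open" are said of these compounds alone.

Compound 1 `CCCC1=C(N2CC2)C(=O)C(C(COC(N)=O)OC)=C(N2CC2)C1=O` gives 5.63 in a functional assay on L1210 cells (Mus musculus), with a stated time of 12 days; a lower number here means a less potent compound, a higher number a more potent compound, by a factor of ten per unit of this negative logarithm.
Compound 2 `CCC1=C(N2CC2)C(=O)C(C(COC(N)=O)OC)=C(N2CC2)C1=O` gives 6.16 in this assay.
Compound 3 `CC1=C(N2CC2)C(=O)C(C(C)COC(N)=O)=C(N2CC2)C1=O` gives 6.41 in this assay.

Compound 3 and compound 2 lie within the scatter of each other, and compound 1 stands below both. The difference between the cores of compound 3 and compound 2 is not broken down here. Between compound 2 and compound 1 a single change was made (methyl in place of hydrogen on a saturated chain carbon, two bonds along the chain from a double-bonded ring carbon), and the result was a number 0.53 log units lower from compound 2 to compound 1 (beyond the scatter). Compound 4 `CCC(COC(N)=O)C1=C(N2CC2)C(=O)C(C)=C(N2CC2)C1=O` is not yet measured; it carries the same change relative to compound 3 (methyl in place of hydrogen on a saturated chain carbon, two bonds along the chain from a double-bonded ring carbon), at the same place. Because the earlier step was a number 0.53 log units lower from compound 2 to compound 1 (beyond the scatter), a drop of about that size is expected from compound 3 to compound 4, namely a number 0.51 log units lower from compound 3 to compound 4 (beyond the scatter). Compound 4 is therefore estimated at 5.9 in this assay, between 5.4 and 6.4.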

Compound 4, logarithm of the reciprocal of the active concentration, log(1/C): 6.18
Compound 4: the middle estimate sits 0.28 log units below what was measured, and the stated range covers the measured number.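

In this assay, methyl in place of hydrogen gives a number 0.23 log units lower from compound 3 to compound 4 (within the scatter). Set beside the earlier step, the new one cannot be told apart from it: the same change on two cores in this assay, a number 0.53 log units lower (beyond the scatter) from compound 2 to compound 1 and a number 0.23 log units lower (within the scatter) from compound 3 to compound 4, 0.30 log units apart, within the scatter of two such steps This agrees with the change carrying over between these two cores, but two steps on two cores do not make a general rule, and the new step on its own cannot be told from no change at all.

The compounds shown leave open whether a longer chain such as butyl, or an amine, at this place would behave in the same way. They also leave open whether the step would hold on any other core.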